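This account rests on a few compounds, and the source may have more. Where it says the series, first, only, none or still open, it means among the compounds named here.

Values so far in a physicochemical assay for solubility, read by HPLC, using the shake flask method, measured as kinetic solubility, with a stated time of 20 h, at pH 6.5, tested at 200 uM; a higher number here means a more soluble compound, a lower number a less soluble compound
compound 1 `c1cc(-c2ccnc3ccc(NC4CC4)nc23)ccn1` gives 90000 nM
compound 2 `O=S(=O)(CCO)c1cccc(-c2ccc3nccc(-c4ccncc4)c3n2)c1` gives 55000 nM
compound 3 `C[C@@H]1CN(S(=O)(=O)c2cccc(-c3ccc4nccc(-c5ccncc5)c4n3)c2)C[C@H](C)N1` gives 180000 nM

Compound 3 at 180000 nM cannot be separated from compound 1 within the scatter, but it stands clear of compound 2. The next structure is compound 4 `Nc1cccc(-c2ccc3nccc(-c4ccncc4)c3n2)c1` with amino in place of (3,5-dimethylpiperazin-1-yl)sulfonyl on an aromatic carbon.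

Within the data shown here, only one measured step bears on this, and only in part (a 3.3-fold higher number from compound 2 to compound 3 (0.51 log units; beyond the scatter)). That modest step has 3,5-dimethylpiperazin-1-yl in place of 2-hydroxyethyl on a sulfonyl sulfur. Among the measured compounds shown here, compound 4 lacks 3,5-dimethylpiperazin-1-yl, as compound 2 does, but it also lacks the sulfonyl, and no measured step covers that loss. For the measured compounds named here, compound 1 gives no single-place step to any other compound.

A lower number is therefore expected in this assay, with a drop somewhat larger than the measured step, and compound 2 at 55000 nM serves as the nearest guide. The estimated change is a 6.0-fold lower number from compound 3 to compound 4 (0.78 log units; beyond the scatter) and it remains an expectation. Going by the values given here, for compound 4 the expected value is 30000 nM with an estimated range of 8000 nM to 100000 nM and no measurement yet to support it.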

Compound 4, solubility: < 5000 nM
Compound 4 gave a limit, no number; the forecaster's own chance of this, stated with the estimate: 10%; at least 6.0-fold (0.77 log units) between middle value and limit.
By their numbers in this assay, from the lowest: compounds 2, 1 and 3 (each within the scatter of the next, the first and the last beyond it). At a limit, below all of these: compound 4.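

In this assay compound 4 returns a limit and no number, the only such result among the values shown: the limit of < 5000 nM in this assay, at which 1 of the 4 values shown sits.

Among these compounds, until now the only measured change at this position was an exchange on the sulfonyl sulfur, and that step was modest (a 3.3-fold higher number from compound 2 to compound 3 (0.51 log units; beyond the scatter)). Amino in place of the whole sulfonyl-bearing group, on an aromatic carbon of the six-membered carbon-only ring and meta to a large group, gives large steps from either sulfonyl compound (an at least 36-fold lower number from compound 3 to compound 4 (1.55 log units; beyond the scatter); an at least 11-fold lower number from compound 2 to compound 4 (1.04 log units; beyond the scatter)), so the choice of sulfonyl substituent matters less here than whether a sulfonyl group is present with its substituent at all. The step from the cyclopropylamino compound is also large (an at least 18-fold lower number from compound 1 to compound 4 (1.25 log units; beyond the scatter)), so compound 4 stands apart from all three earlier compounds, although that step changes a different group on the shared core.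

On these data alone, the true size of all three steps stays open, as each ends at a limit, and nothing here separates the loss of the sulfonyl from the arrival of the amino group. Also open, as far as these compounds go, is how a dimethylamino group, an acetamide or a carboxylic acid on this aromatic carbon would read in this assay.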